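The source may hold more compounds than are shown below. What is called first, only, known or untested is meant among the compounds shown, and "the series" means these compounds.

Working notes on the series

Three compounds of the shared core have numbers in a functional assay on HeLa cells (Homo sapiens) for antiproliferative activity, read by sulforhodamine B assay, with a stated time of 48 h; on this read-out lower numbers stand for stronger inhibition and higher numbers for weaker inhibition. Compound 1 `COc1cc(C(=O)/C=C\Nc2ccc(-c3nc4cc(OC)c(OC)c(OC)c4s3)cc2)c(Br)c(OC)c1OC` gives 6600 nM in this assay. Compound 2 `COc1cc(C(=O)/C=C\Nc2ccc(-c3nc4cc(OC)c(OC)c(OC)c4s3)cc2C)cc(OC)c1OC` gives 11100 nM in this assay. Compound 3 `COc1cc(OC)c2sc(-c3ccc(N/C=C\C(=O)c4cc(OC)c(OC)c(OC)c4)cc3)nc2c1` gives 17800 nM in this assay. Among the measured compounds shown here, on these three numbers compound 2 stands second highest; its nearest neighbour is compound 3, and the gap between them is within the scatter, as is the gap to compound 1, so the three values cannot be ordered against each other and no step between measured compounds is established.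

Compound 4 `COc1ccc(C(=O)/C=C\Nc2ccc(-c3nc4cc(OC)c(OC)c(OC)c4s3)cc2C)cc1F` is not yet measured in this assay. It differs from compound 2 by 3-fluoro-4-methoxyphenyl in place of 3,4,5-trimethoxyphenyl on a carbonyl carbon. For the measured compounds named here, the change removes two of the three hydrogen-bond acceptors counted on the leaving group and brings in a fluorine; nothing among the measured compounds touches this position, so no measured step supports the expectation. Going by the values given here, with the three measured values sitting close together and no analogue at the carbonyl side, the expected step from compound 2 to compound 4 is estimated as a 1.4-fold higher number from compound 2 to compound 4 (0.13 log units; within the scatter), a move toward weaker inhibition of uncertain size, possibly not beyond the scatter. Compound 4 is estimated to give 15000 nM in this assay, within a range from 5000 nM to 50000 nM.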

Compound 4, half-maximal inhibitory concentration: 1200 nM
Compound 4: middle estimate off by 13-fold (1.10 log units), on the high side; the whole stated range lies above it.
By their numbers in this assay, from the lowest: compound 4; then compounds 1, 2 and 3 (each within the scatter of the next, the first and the last beyond it).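

In this assay, the aryl group on the carbonyl carbon turns out to be a place where one change moves the number beyond the scatter: 3-fluoro-4-methoxyphenyl in place of 3,4,5-trimethoxyphenyl gives a 9.3-fold lower number from compound 2 to compound 4 (0.97 log units; beyond the scatter), toward stronger inhibition. Among the compounds shown here, the earlier compounds offered no step at all, so this single pair is the first measured sign that the series responds to a change at this position, and it shows that all three methoxy groups of the leaving group are not needed for activity in this compound. No supporting measurement bears on why the number moves, so the step stands as an observation without an explanation.

The exchange alters the group as a whole, so the compounds shown leave open how much of the step belongs to the fluorine and how much to the departure of the methoxy groups. Also open, as far as these compounds go, is how this carbonyl carbon would read with an unsubstituted phenyl, or with an aryl group carrying an amine or a carboxylic acid, and whether the step carries over to other members.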